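Working notes: from compound 3 to compound 4

This account rests on a few compounds, and the source may have more. Where it says the series, first, only, none or still open, it means among the compounds named here.

Growth data so far in a functional assay on SK-OV-3 cells (Homo sapiens) (a higher number here means a weaker inhibitor of growth, a lower number a stronger inhibitor of growth), are as follows
- compound 1 `O=S(=O)(/C=C/c1ccc(F)cc1)Cc1ccc(Nc2ncnc3ccccc23)cc1` gives 2000 nM
- compound 2 `N#Cc1ccc(/C=C/S(=O)(=O)Cc2ccc(Nc3ncnc4ccccc34)cc2)cc1` gives > 100000 nM as a limit of the assay
- compound 3 `O=S(=O)(/C=C/c1ccc(C(F)(F)F)cc1F)Cc1ccc(Nc2ncnc3ccccc23)cc1` gives 39000 nM
- compound 4 `O=S(=O)(/C=C/c1ccc(O)cc1)Cc1ccc(Nc2ncnc3ccccc23)cc1` is not yet measured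

Compound 3 holds the higher of the two exact values. The nearest exact value lies behind a 20-fold higher number from compound 1 to compound 3 (1.29 log units; beyond the scatter) and that step is large. The other bound is an at least 2.5-fold lower number from compound 2 to compound 3 (0.40 log units; beyond the scatter) and it rests on a limit of the assay.

Within the data shown here, the next change is 4-hydroxyphenyl in place of 2-fluoro-4-(trifluoromethyl)phenyl on a double-bonded chain carbon bound to a double-bonded chain carbon and no measured compound carries the entering group. Single changes of this group have already moved the number far, as an at least 50-fold higher number from compound 1 to compound 2 (1.69 log units; beyond the scatter) also shows, and that step warns that a new group can raise it too. With compound 3 at 39000 nM high in this small set, a lower number is still expected, moving toward compound 1 at 2000 nM without certainty of reaching it. The expected change is a 6.5-fold lower number from compound 3 to compound 4 (0.81 log units; beyond the scatter) in this assay and it is estimated to lie beyond the scatter. For compound 4 the estimate is 6000 nM with an expected range of 1200 nM to 40000 nM in this wide window.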

Compound 4, concentration for 50% growth inhibition: 14000 nM
Compound 4: the middle estimate sits 2.3-fold (0.37 log units) below what was measured, and the stated range covers the measured number.
By their numbers in this assay, from the lowest: compound 1; then compound 4; then compound 3. At a limit, above all of these: compound 2.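

In this assay, 4-hydroxyphenyl on this double-bonded chain carbon gives a 2.8-fold lower number from compound 3 to compound 4 (0.44 log units; beyond the scatter), so this group improves on 2-fluoro-4-(trifluoromethyl)phenyl, though only modestly. The entering group, with its hydrogen-bond donor, still does not match 4-fluorophenyl, as a 7.0-fold higher number from compound 1 to compound 4 (0.85 log units; beyond the scatter) shows. Hydroxy in place of cyano gives an at least 7.1-fold lower number from compound 2 to compound 4 (0.85 log units; beyond the scatter), a step that rests on a limit of the assay for compound 2: the limit of > 100000 nM in this assay, at which 1 of the 4 values shown sits.

From the compounds shown here alone, whether an amine, a methoxy group or a carboxylic acid on this aromatic carbon would fall nearer to fluoro or to hydroxy stays open. The compounds shown give no measured property that would explain this order.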